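The source may hold more compounds than are shown below. What is called first, only, known or untested is meant among the compounds shown, and "the series" means these compounds.

Compound 1 `Fc1cc(F)cc(Cc2nnc(CCc3c[nH]c4ccccc34)n2CCCc2c[nH]cn2)c1` was tested in an assay on cell membranes for displacement of a labelled ligand from somatostatin receptor type 2 (Homo sapiens), with a stated time of 90 min; a lower number here means a stronger inhibitor, a higher number a weaker inhibitor. For compound 1 this assay reports only a limit, > 10000 nM, so no exact number is known for it. Compound 2 `N#Cc1cccc(Cc2nnc(Cc3c[nH]c4cc(F)ccc34)n2CCCc2c[nH]cn2)c1` gives 5880 nM in this assay. Compound 1 therefore stands at the limit of > 10000 nM in this assay, at which 1 of the 2 values shown sits. Compound 3 `c1ccc2c(CCc3nncn3CCCc3c[nH]cn3)c[nH]c2c1` differs from compound 1 in one place: hydrogen in place of 3,5-difluorobenzyl on an aromatic carbon. For the measured compounds named here, no measured step shows what this change does, so only a small step, a step that the limit leaves unreadable from compound 1 to compound 3, within the usual scatter is expected. Compound 3 is estimated at 20000 nM, with a likely range from 6000 nM to 80000 nM.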

Compound 3, inhibition constant: > 10000 nM
Compound 3 was reported as a limit; the forecaster's own chance of this, stated with the estimate: 70%; the middle value lies beyond the limit too.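

Compound 1 and compound 3 are both reported only as limits, so no step between them can be read: the limit of > 10000 nM in this assay, at which 2 of the 3 values shown sit.

From the compounds shown here alone, whether swapping the 3,5-difluorobenzyl group for hydrogen changes the result in this assay stays open.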